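The compounds below may be only part of what the source reports. "The series", "measured", "known", "first", "only" and "open" are said of these compounds alone.

In an assay on brain for binding affinity to Adrenergic receptor alpha-1 (Rattus norvegicus) (on this read-out higher numbers stand for weaker inhibition and lower numbers for stronger inhibition), compound 2 `COc1cc2nc(N3CCN(c4ccncn4)CC3)nc(N)c2cc1OC` gives 0.27 nM, and compound 1 `COc1cc2nc(N3CCN(c4ncccn4)CC3)nc(N)c2cc1OC` gives 0.26 nM, the two within the scatter of each other, so on the numbers shown compound 2 simply sits alongside compound 1. Among the compounds with values here, the one measured step, a 1.0-fold higher number from compound 1 to compound 2 (0.02 log units; within the scatter), swapped one aromatic ring for another of the same size and changed nothing beyond the scatter. Compound 3 `COc1cc2nc(N3CCN(c4cccnn4)CC3)nc(N)c2cc1OC` makes a swap of the same kind: pyridazin-3-yl in place of pyrimidin-4-yl on an amine nitrogen in a ring. With that single step as guide, the expected step is a 1.1-fold higher number from compound 2 to compound 3 (0.05 log units; within the scatter), nothing beyond the scatter in this assay. Compound 3 is therefore estimated at 0.3 nM, likely between 0.1 nM and 0.9 nM.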

Compound 3, inhibition constant: 0.4 nM
Estimate against measurement, compound 3: 1.3-fold (0.12 log units) below, within the range that was stated.
By their numbers in this assay, from the lowest: compounds 1, 2 and 3 (each within the scatter of the next).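

In this assay the result is a 1.5-fold higher number from compound 2 to compound 3 (0.17 log units; within the scatter) and a 1.5-fold higher number from compound 1 to compound 3 (0.19 log units; within the scatter) for pyridazin-3-yl on the amine nitrogen in the ring. A third six-membered aromatic ring with the same atoms, joined differently, therefore adds to the single earlier comparison, and no step among these three compounds lies beyond the scatter. Nothing measured here explains why these rings give such similar numbers. Still open, from the compounds shown here alone, is how the number would respond at this place to a phenyl ring, which has no ring nitrogen, or to a carboxylic acid.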